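The compounds below may be only part of what the source reports. "The series", "measured", "known", "first", "only" and "open" are said of these compounds alone.

Measured so far in a functional assay on HL-60 cells (Homo sapiens) for cytotoxicity, read by MTT assay, with a stated time of 24 h; a higher number here means a weaker inhibitor, a lower number a stronger inhibitor:
compound 1, `COC(=O)/C(=C\c1ccc(O)cc1)Sc1ccnc2cc(Cl)ccc12`: 4310 nM
compound 2, `COC(=O)/C(=C\c1ccc(OC(=O)c2ccccc2)cc1)Sc1ccnc2cc(Cl)ccc12`: 30200 nM

Going by the values given here, compound 2 stands highest of the two numbers in this assay; its nearest neighbour is compound 1, with a 7.0-fold higher number from compound 1 to compound 2 (0.85 log units; beyond the scatter) as the only measured step, a modest weakening on benzoyl in place of hydrogen.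

Compound 3, `COC(=O)/C(=C\c1ccc(OC(=O)c2ccc(OC)cc2)cc1)Sc1ccnc2cc(Cl)ccc12`, differs from compound 2 by methoxy in place of hydrogen on an aromatic carbon. Among the compounds with values here, no measured step covers this change; the step from compound 1 to compound 2 tells only that enlarging this part of the molecule weakened inhibition modestly. Compound 3 is therefore expected to stay near compound 2, with a step of a 1.2-fold higher number from compound 2 to compound 3 (0.06 log units; within the scatter), and an estimated value of 35000 nM (range 15000 nM to 80000 nM).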

Compound 3, half-maximal inhibitory concentration: 9090 nM
For compound 3 the middle estimate is 3.9-fold (0.59 log units) above the measured one; measured number outside the range, below it.
By their numbers in this assay, from the lowest: compound 1; then compound 3; then compound 2.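

In this assay the benzoyl group is sensitive to substitution on its ring: methoxy in place of hydrogen gives a 3.3-fold lower number from compound 2 to compound 3 (0.52 log units; beyond the scatter), recovering part of what benzoyl cost. Acylating the hydroxyl therefore carries no fixed penalty: (4-methoxyphenyl)carbonyl still leaves a 2.1-fold higher number from compound 1 to compound 3 (0.32 log units; beyond the scatter), a smaller step than a 7.0-fold higher number from compound 1 to compound 2 (0.85 log units; beyond the scatter). Nothing at hand bears on the cause of this shift. Going by these compounds, whether the gain is specific to methoxy remains open. A fluorine or a dimethylamino group at the same place, or an acetyl in place of the benzoyl, would address this.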